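The source may report more compounds than this note shows. Statements on the series, on what has been measured and on what is new or still open speak of the compounds shown alone.

Measured compounds: compound 1 `CC(C)(C)C[N+]1(C)CCc2c(sc(NC(=O)Nc3ccc(Cl)cc3)c2C(N)=O)C1` gives 290 nM; compound 2 `CC(C)C[N+]1(C)CCc2c(sc(NC(=O)Nc3ccc(Cl)cc3)c2C(N)=O)C1` gives 380 nM; compound 3 `CC[N+]1(C)CCc2c(sc(NC(=O)Nc3ccc(Cl)cc3)c2C(N)=O)C1` gives 1960 nM, all in a functional assay (strain AB) with Danio rerio as the target, read by microscopy, with a stated time of 1 h; on this read-out lower numbers stand for an effect already at smaller amounts and higher numbers for an effect only at larger amounts of compound.

The three share one core, and the difference between compound 2 and compound 3 is methyl in place of isopropyl on a saturated chain carbon bound to an amine nitrogen in a ring, which gave a 5.2-fold higher number from compound 2 to compound 3 (0.71 log units; beyond the scatter). Within the measured set the change methyl in place of hydrogen on a saturated chain carbon bound to three saturated chain carbons made a 1.3-fold lower number from compound 2 to compound 1 (0.12 log units; within the scatter). Compound 4 `CC[N+]1(CC)CCc2c(sc(NC(=O)Nc3ccc(Cl)cc3)c2C(N)=O)C1` arises from compound 3 by methyl in place of hydrogen on a saturated chain carbon bound to an amine nitrogen in a ring, the same kind of change, though the place differs: in compound 1 the carbon is bound to three saturated chain carbons, whereas in compound 4 it is bound to an amine nitrogen in a ring. Because a 6.8-fold higher number from compound 1 to compound 3 (0.83 log units; beyond the scatter) shows that more carbon on this carbon lowers the number, compound 4 is expected to move somewhat, estimated as a 2.0-fold lower number from compound 3 to compound 4 (0.29 log units; within the scatter). The estimate for compound 4 is 1000 nM, between 400 nM and 2500 nM.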

Compound 4, half-maximal effective concentration: 450 nM
Beside the measured number, compound 4's estimate is 2.2-fold (0.35 log units) above it; the measured number falls inside the stated range.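

In this assay, methyl in place of hydrogen on a saturated chain carbon bound to an amine nitrogen in a ring gave a 4.4-fold lower number from compound 3 to compound 4 (0.64 log units; beyond the scatter). Set beside the earlier case of the same change, the two steps differ in size: the same change on two cores in this assay, a 1.3-fold lower number (0.12 log units; within the scatter) from compound 2 to compound 1 and a 4.4-fold lower number (0.64 log units; beyond the scatter) from compound 3 to compound 4, 3.3-fold (0.52 log units) apart, beyond the scatter of two such steps This shows that the size of the step did not carry over from one core to the other, but it does not show why, since the two pairs differ in the place of the change as well as in the core, and two pairs give no rule for further cores.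

The compounds shown leave open how a longer chain, such as propyl or butyl, would read in place of the ethyl groups of compound 4. They also leave open how a chain ending in a carboxylic acid would read there.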